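The compounds below may be only part of what the source reports. "The series", "measured", "known", "first", "only" and "open" are said of these compounds alone.

Of the compounds shown here, three sharing a common core have been tested in an assay on CHO cells for displacement of a labelled ligand from histamine receptor H3 (Macaca mulatta), read by scintillation counting, with a stated time of 1 h; a higher number here means a weaker inhibitor, a lower number a stronger inhibitor. Compound 1 `CC(=O)N1CCN(C(=O)Nc2ccc(N3CCC(N4CCCC4C)C3)cc2)CC1` gives 34.1 nM. Compound 2 `CC(=O)N1CCN(C(=O)Nc2ccc(N3CCC(N4CCCC4C)C3)c(C)c2)CC1` differs from compound 1 only by methyl in place of hydrogen on an aromatic carbon, and compound 2 gives 23 nM; the step is a 1.5-fold lower number from compound 1 to compound 2 (0.17 log units; within the scatter). Compound 3 `CC(=O)N(C)C1CCN(C(=O)Nc2ccc(N3CCC(N4CCCC4C)C3)cc2)C1` carries a different core, the difference being (3-(acetyl(methyl)amino)pyrrolidin-1-yl in place of 4-acetylpiperazin-1-yl on a carbonyl carbon), and compound 3 gives 35.5 nM, a step of a 1.0-fold higher number from compound 1 to compound 3 (0.02 log units; within the scatter). Compound 4 `CC(=O)N(C)C1CCN(C(=O)Nc2ccc(N3CCC(N4CCCC4C)C3)c(C)c2)C1` has not yet been measured. It differs from compound 3 by methyl in place of hydrogen on an aromatic carbon, the same change already seen between compound 1 and compound 2, at a place described in identical words. Because the earlier step of a 1.5-fold lower number from compound 1 to compound 2 (0.17 log units; within the scatter) was small, a step of similar size is expected here, namely a 1.5-fold lower number from compound 3 to compound 4 (0.17 log units; within the scatter). On that basis compound 4 is estimated to give 24 nM, most likely between 12 nM and 50 nM.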

Compound 4, inhibition constant: 89.7 nM
Beside the measured number, compound 4's estimate is 3.7-fold (0.57 log units) below it; the measured number lies above the stated range.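

In this assay, the effect of methyl in place of hydrogen on an aromatic carbon did not carry over from one core to the other, and on the core of compound 3 the change gave a 2.5-fold higher number from compound 3 to compound 4 (0.40 log units; beyond the scatter): the same change on two cores in this assay, a 1.5-fold lower number (0.17 log units; within the scatter) from compound 1 to compound 2 and a 2.5-fold higher number (0.40 log units; beyond the scatter) from compound 3 to compound 4, 3.7-fold (0.57 log units) apart, beyond the scatter of two such steps
Seen from the other side, the exchange of 4-acetylpiperazin-1-yl for 3-(acetyl(methyl)amino)pyrrolidin-1-yl, with the methyl present, gave a 3.9-fold higher number from compound 2 to compound 4 (0.59 log units; beyond the scatter): the same change on two cores in this assay, a 1.0-fold higher number (0.02 log units; within the scatter) from compound 1 to compound 3 and a 3.9-fold higher number (0.59 log units; beyond the scatter) from compound 2 to compound 4, 3.7-fold (0.57 log units) apart, beyond the scatter of two such steps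
So in these four compounds the two changes do not simply add up, but this does not show why, and a single pair of cores cannot predict how the methyl would behave on another core.

As far as these compounds go, it remains open whether chlorine, methoxy or ethyl on that aromatic carbon would split between the two cores in the same way.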